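Compound 2 to compound 4: losing the diethylamino chain

This account rests on a few compounds, and the source may have more. Where it says the series, first, only, none or still open, it means among the compounds named here.

Values in a functional assay on PC-3 cells (Homo sapiens), read by MTT assay, with a stated time of 48 h; a lower number here means a stronger inhibitor, a higher number a weaker inhibitor:
- compound 1 `CCOC(=O)CN(C)C(=O)c1ccc(C(CC)(CC)c2ccc(OCC(O)C(C)(C)C)c(C)c2)n1CC`: 25500 nM
- compound 2 `CCN(CC)CCNC(=O)c1ccc(C(CC)(CC)c2ccc(OCC(O)C(C)(C)C)c(C)c2)n1CC`: 220 nM
- compound 3 `CCN(CC)CCCNC(=O)c1ccc(C(CC)(CC)c2ccc(OCC(O)C(C)(C)C)c(C)c2)n1CC`: 2500 nM

Compound 2, at 220 nM, holds the lowest number of the three. The next compound to read is compound 4 `C=CCN(C)C(=O)c1ccc(C(CC)(CC)c2ccc(OCC(O)C(C)(C)C)c(C)c2)n1CC`, with allyl(methyl)amino in place of (2-(diethylamino)ethyl)amino on a carbonyl carbon.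

The closest evidence is a 120-fold lower number from compound 1 to compound 2 (2.06 log units; beyond the scatter), a large step that brings in the same (2-(diethylamino)ethyl)amino in place of ((ethoxycarbonyl)methyl)(methyl)amino. Compound 4 runs the other way, leaving that group behind. The step of a 10-fold lower number from compound 1 to compound 3 (1.01 log units; beyond the scatter) is also large, and an 11-fold higher number from compound 2 to compound 3 (1.06 log units; beyond the scatter) shows a large move even with diethylamino kept. Only compound 1 lacks diethylamino among the measured compounds, so this reading rests on one comparison.

A large move to a higher number is expected, a 68-fold higher number from compound 2 to compound 4 (1.83 log units; beyond the scatter). For compound 4 the estimate is 15000 nM, with an expected range of 4000 nM to 50000 nM.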

Compound 4, half-maximal inhibitory concentration: 25900 nM
Estimate against measurement, compound 4: 1.7-fold (0.24 log units) below; low and high end bracket the measured number.
By their numbers in this assay, from the lowest: compound 2; then compound 3; then compounds 1 and 4 (each within the scatter of the next).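

In this assay, the steps of a 120-fold higher number from compound 2 to compound 4 (2.07 log units; beyond the scatter) and a 10-fold higher number from compound 3 to compound 4 (1.02 log units; beyond the scatter) show that the advantage of the diethylamino chains over compound 1 also holds against a second compound without diethylamino. The step of a 1.0-fold higher number from compound 1 to compound 4 (0.01 log units; within the scatter), with vinyl in place of ethoxycarbonyl, shows that these two groups cannot be told apart at this position, so the change on that saturated chain carbon does not alter the reading here. Nothing available bears on why the number moves when the diethylamino chain leaves.

The compounds shown leave open whether the diethylamino group or the amide hydrogen accounts for the lower numbers of compound 2 and compound 3. (2-(Diethylamino)ethyl)(methyl)amino on the carbonyl carbon would keep the chain without that hydrogen, while ethylamino would keep the hydrogen without the diethylamino group.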